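Swapping ethynyl for iodo on a nucleoside scaffold

A few compounds are considered here, and "the series" means these few. Any claim that something is new, unique, unknown or untested is made for them only; others in the source may bear on it.

Compound 1, `Cc1ncnc2c1c(I)cn2[C@@H]1O[C@H](CO)[C@@H](O)[C@H]1O`, in an ADME assay on BJ cells (Homo sapiens), read by MTT assay, with a stated time of 72 h (on this read-out higher numbers stand for weaker inhibition and lower numbers for stronger inhibition), gives > 100000 nM, which is a limit of the assay and not a number.
Compound 2, `C#Cc1cn([C@@H]2O[C@H](CO)[C@@H](O)[C@H]2O)c2ncnc(C)c12`, in this assay gives 50 nM.
Compound 3, `C#Cc1cn([C@@H]2O[C@H](CO)[C@@H](O)[C@H]2O)c2ncnc(NC)c12`, in this assay gives 86000 nM.

Compound 4, `CNc1ncnc2c1c(I)cn2[C@@H]1O[C@H](CO)[C@@H](O)[C@H]1O`, has not been measured. It differs from compound 3 by iodo in place of ethynyl on an aromatic carbon. The same change, (iodo in place of ethynyl on an aromatic carbon), has been measured once: an at least 2000-fold higher number from compound 2 to compound 1 (3.30 log units; beyond the scatter), a step that ends at the limit of > 100000 nM in this assay, at which 1 of the 3 values shown sits. The cores of compound 3 and compound 2 differ by methylamino in place of methyl on an aromatic carbon, a change that gave a 1700-fold higher number from compound 2 to compound 3 (3.24 log units; beyond the scatter). Compound 3 already stands highest of the two numbers, and compound 4 adds to it a change that lost greatly elsewhere. Compound 4 is therefore expected to give 300000 nM, between 90000 nM and 1000000 nM, most likely reported only as a limit. The expected step, a 3.5-fold higher number from compound 3 to compound 4 (0.54 log units; beyond the scatter), rests on an at least 2000-fold higher number from compound 2 to compound 1 (3.30 log units; beyond the scatter).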

Compound 4, half-maximal inhibitory concentration: > 100000 nM
Compound 4: a limit, no number; the forecaster's own chance of this, stated with the estimate: 85%; the middle value does not contradict the limit.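

In this assay compound 4 sits at a limit of the assay and not at a number. Carrying iodo in place of ethynyl onto the core of compound 3 therefore gives only a floor, an at least 1.1-fold higher number from compound 3 to compound 4 (0.06 log units; that floor lies within the scatter), which fits a higher number on this core but does not prove one. Set beside the earlier step, the result shows neither that the change carries over at the same size nor that its size differs: the same change on two cores in this assay, an at least 2000-fold higher number (3.30 log units; beyond the scatter) from compound 2 to compound 1 and an at least 1.1-fold higher number (0.06 log units; that floor lies within the scatter) from compound 3 to compound 4; the limit leaves it open whether they differ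

From the compounds shown here alone, with a limit at both ends, the step from compound 1 to compound 4 cannot be read, so the effect of methylamino in place of methyl on the iodo core stays open. Also open, going by these compounds, is whether a group such as bromo or a longer chain such as propynyl, on the same aromatic carbon, would stay close to compound 2 at 50 nM.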